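The source may report more compounds than this note shows. Statements on the series, on what has been measured and on what is new or still open speak of the compounds shown alone.

Measured compounds:
- compound 1 `CN(C)CCn1cnnc1-c1cc(Oc2ccc(NC(=O)N/N=C/c3ccc(Cl)cc3)cc2F)ccn1`: 530 nM in a functional assay on HT-29 cells (Homo sapiens) for cytotoxicity, read by MTT assay, with a stated time of 72 h; a lower number here means a stronger inhibitor, a higher number a weaker inhibitor
- compound 2 `CN(C)CCn1cnnc1-c1cc(Oc2ccc(NC(=O)N/N=C/c3ccc(O)c(Br)c3)cc2F)ccn1`: 450 nM
- compound 3 `Cc1cc(/C=N/NC(=O)Nc2ccc(Oc3ccnc(-c4nncn4CCN(C)C)c3)c(F)c2)cc(C)c1O`: 1220 nM

Compound 1 holds the second-highest of these three numbers. Its nearest neighbour is compound 2, reached by a step of a 1.2-fold lower number from compound 1 to compound 2 (0.07 log units; within the scatter); its furthest is compound 3, reached by a 2.3-fold higher number from compound 1 to compound 3 (0.36 log units; beyond the scatter). Compound 4 `COc1ccc(/C=N/NC(=O)Nc2ccc(Oc3ccnc(-c4nncn4CCN(C)C)c3)c(F)c2)c(OC)c1OC` differs from compound 1 in one place: 2,3,4-trimethoxyphenyl in place of 4-chlorophenyl on a carbon with a double bond to nitrogen. Among the measured compounds shown here, two steps bear on this change. Compound 1 to compound 2 stayed within the scatter, while compound 1 to compound 3, where a more heavily substituted ring entered, rose modestly, as did a 2.7-fold higher number from compound 2 to compound 3 (0.43 log units; beyond the scatter). A modest rise is therefore expected, with a 1.7-fold higher number from compound 1 to compound 4 (0.23 log units; within the scatter). Compound 4 is estimated at 900 nM, with a range from 400 nM to 2500 nM.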

Compound 4, half-maximal inhibitory concentration: 3970 nM
The estimate for compound 4 lay 4.4-fold (0.64 log units) below the measured number; measured number above the stated range.
By their numbers in this assay, from the lowest: compounds 2 and 1 (each within the scatter of the next); then compound 3; then compound 4.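

In this assay, among the compounds shown here, the group on this carbon turns out to matter more than the earlier compounds showed: 2,3,4-trimethoxyphenyl in place of 4-chlorophenyl gives a 7.5-fold higher number from compound 1 to compound 4 (0.87 log units; beyond the scatter), and the other comparisons give an 8.8-fold higher number from compound 2 to compound 4 (0.95 log units; beyond the scatter) and a 3.3-fold higher number from compound 3 to compound 4 (0.51 log units; beyond the scatter). All three steps lie beyond the scatter, making compound 4 the weakest of the four. Nothing measured here accounts for this rise. How 4-methoxyphenyl, carrying a single methoxy group, would compare stays open, so the compounds shown cannot tell whether one methoxy group or all three go with the higher number.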